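The source may hold more compounds than are shown below. What is called first, only, known or untested is meant among the compounds shown, and "the series" means these compounds.

Working notes on the series

For the measured compounds named here, compound 1 `COc1ccc(C(=O)Nc2cccc(-c3oc4cc(-c5ccc(F)cc5)ccc4c(=O)c3O)c2)cc1` is the weakest of the three measured members: in a functional assay on MDA-MB-231 cells (Homo sapiens) for antiproliferative activity, read by CCK-8 assay, with a stated time of 72 h (a higher number here means a weaker inhibitor, a lower number a stronger inhibitor), compound 1 gives 16500 nM. Compound 2 `Cc1ccccc1C(=O)Nc1cccc(-c2oc3cc(-c4ccc(F)cc4)ccc3c(=O)c2O)c1` gives 4910 nM and compound 3 `COc1cc(OC)cc(C(=O)Nc2cccc(-c3oc4cc(-c5ccc(F)cc5)ccc4c(=O)c3O)c2)c1` gives 4040 nM. Compound 2 thus sits second highest of the three numbers; its nearest neighbour is compound 3, at a 1.2-fold lower number from compound 2 to compound 3 (0.08 log units; within the scatter), and its furthest is compound 1, at a 3.4-fold lower number from compound 1 to compound 2 (0.53 log units; beyond the scatter).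

Compound 4 `Cc1cc(C)cc(C(=O)Nc2cccc(-c3oc4cc(-c5ccc(F)cc5)ccc4c(=O)c3O)c2)c1` has not yet been measured. Relative to compound 2 the change is 3,5-dimethylphenyl in place of 2-methylphenyl on a carbonyl carbon. Going by the values given here, the step that bears most directly on it is the one from compound 2 to compound 3, which also replaces the 2-methylphenyl by a 3,5-disubstituted phenyl, and that step was a 1.2-fold lower number from compound 2 to compound 3 (0.08 log units; within the scatter). The step of a 4.1-fold lower number from compound 1 to compound 3 (0.61 log units; beyond the scatter) shows the same 3,5-pattern reaching the lower end of the measured range. Among the compounds with values here, no measured pair separates a methyl from a methoxy at those positions, so the expectation for compound 4 rests on the 3,5-pattern alone.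

The expected step from compound 2 is a 1.2-fold lower number from compound 2 to compound 4 (0.09 log units; within the scatter), within the scatter. Compound 4 is therefore estimated at 4000 nM, with a likely range of 1800 nM to 9000 nM.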

Compound 4, half-maximal inhibitory concentration: 11900 nM
Estimate against measurement, compound 4: 3.0-fold (0.47 log units) below, outside the stated range (above it).
By their numbers in this assay, from the lowest: compounds 3 and 2 (each within the scatter of the next); then compounds 4 and 1 (each within the scatter of the next).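

In this assay, for the compounds shown here, the 3,5-pattern alone does not set the number on this carbonyl carbon: 3,5-dimethylphenyl in place of 3,5-dimethoxyphenyl gives a 2.9-fold higher number from compound 3 to compound 4 (0.47 log units; beyond the scatter) and so separates methyl from methoxy at the same positions for the first time. Set against the 2-methylphenyl of compound 2, the same group gives a 2.4-fold higher number from compound 2 to compound 4 (0.38 log units; beyond the scatter) while a 1.4-fold lower number from compound 1 to compound 4 (0.14 log units; within the scatter) leaves 3,5-dimethylphenyl and 4-methoxyphenyl indistinguishable here. Nothing available explains why the 3,5-dimethyl and 3,5-dimethoxy compounds part.

Open is whether both methoxy groups of compound 3 are needed for its value, as no compound shown carries a single methoxy at either of those positions. Also open, from the compounds shown here alone, is what a 3,5-dichlorophenyl or a phenyl bearing an amine or a carboxylic acid would give on this carbonyl carbon.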